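Trifluoromethyl on the triazole phenyl of a brominated core

The source may hold more compounds than are shown below. What is called first, only, known or untested is meant among the compounds shown, and "the series" means these compounds.

The compounds here share a core with a triazole carrying a phenyl ring, and are tested in a functional assay on SMMC-7721 cells (Homo sapiens) for cytotoxicity, read by MTT assay, with a stated time of 4 days; a higher number here means a weaker inhibitor, a lower number a stronger inhibitor. Compound 1, `C=C1C[C@]23C[C@@]1(O)CC[C@H]2c1ccc(O)c(C)c1[C@@H]3Cn1cc(-c2ccccc2)nn1`, gives only a limit of the assay and no number in this assay, namely > 20000 nM. Compound 2, `Cc1c(O)ccc2c1[C@H](Cn1cc(-c3ccc(C(F)(F)F)cc3)nn1)[C@@]13CC(=O)[C@@](C)(CC[C@@H]21)C3`, which already carries a trifluoromethyl on its phenyl ring, also reaches only a limit in this assay, > 20000 nM. Compound 3, `C=C1C[C@]23C[C@@]1(O)CC[C@H]2c1cc(Br)c(O)c(C)c1[C@@H]3Cn1cc(-c2ccccc2)nn1`, stands at a limit as well, > 20000 nM. Among the measured compounds shown here, the one measured step, a step that the two limits leave unreadable from compound 1 to compound 3, therefore cannot be read, because of the limit of > 20000 nM in this assay, at which 3 of the 3 values shown sit, so that both ends of the step are limits rather than numbers.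

Compound 4, `C=C1C[C@]23C[C@@]1(O)CC[C@H]2c1cc(Br)c(O)c(C)c1[C@@H]3Cn1cc(-c2ccc(C(F)(F)F)cc2)nn1`, is the compound not yet measured. It differs from compound 3 only in trifluoromethyl in place of hydrogen on an aromatic carbon. No measured step bears on this change directly; what can be said is that every compound shown, including compound 2 with the same trifluoromethyl group, sits at the limit of this assay. The expectation for the step from compound 3 to compound 4 is therefore no readable change, a step that the limit leaves unreadable from compound 3 to compound 4, with compound 4 most likely also returning a limit. Compound 4 is thus estimated at 30000 nM, with a range from 8000 nM to 100000 nM.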

Compound 4, half-maximal inhibitory concentration: 12800 nM
Estimate against measurement, compound 4: 2.3-fold (0.37 log units) above; low and high end bracket the measured number.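

Among the compounds shown here, compound 4 is the first compound here to give a real number rather than a limit in this assay, which shows that the phenyl ring on the triazole is a place where one change can bring a reading within the range of the test: compound 4 gives 12800 nM. Going from phenyl to 4-(trifluoromethyl)phenyl on the brominated core amounts to an at least 1.5-fold lower number from compound 3 to compound 4 (0.19 log units; that floor lies within the scatter). That figure is a floor and not a measured size, as compound 3 gives only a limit, so the true change may be larger, but the data do not place it beyond the usual scatter, and most of the series still yields no number: the limit of > 20000 nM in this assay, at which 3 of the 4 values shown sit.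

The compounds shown do not tell whether trifluoromethyl at this place would give a number on the core of compound 1, without the bromo, or whether the bromo is needed for the reading. They also leave open what other groups would do at this same place on the phenyl ring, such as a chlorine atom, a nitrile, an amine or a carboxylic acid.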